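Trimming the alkoxy chain on a cinnamoyl cyclohexenedione core

The source may report more compounds than this note shows. Statements on the series, on what has been measured and on what is new or still open speak of the compounds shown alone.

This account follows a single change made on a cinnamoyl cyclohexenedione core. Compound 1 `CCCC1=C(OC)C(CCC)(CCC)C(=O)/C(=C(O)\C=C\c2ccccc2)C1=O` carries a methoxy group on the shared core and in a functional assay on 1A9 cells (Homo sapiens) for antiproliferative activity, read by sulforhodamine B assay, with a stated time of 3 days (a higher number here means that more compound is needed for the effect, a lower number that less compound is needed), compound 1 gives 3.7 uM. Compound 2 `CCCCOC1=C(CCC)C(=O)/C(=C(O)/C=C/c2ccccc2)C(=O)C1(CCC)CCC` carries a butoxy group in the matching position, but in this assay compound 2 gives "not determined" (no result reported), so no single number places it and nothing can be said about how it compares with compound 1.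

Compound 3 `CCCOC1=C(CCC)C(=O)/C(=C(O)/C=C/c2ccccc2)C(=O)C1(CCC)CCC` is the propoxy analogue, and it is to be tested in this assay. The difference between compound 2 and compound 3 is hydrogen in place of methyl on a saturated chain carbon, three bonds along the chain from an oxygen on an unsaturated carbon. Going by the values given here, no measured pair in the set shows what such a shortening does, so the size of the step from compound 2 to compound 3 in this assay cannot be read from the data; the author expects it to stay within the usual scatter, in no fixed direction. Taking compound 1 as the only anchor, compound 3 is expected to give about 4 uM in this assay, within a range of 1.5 uM to 12 uM.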

Compound 3, concentration for half-maximal effect: 2 uM
Compound 3: middle estimate off by 2.0-fold (0.30 log units), on the high side; measured number inside the range.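

In this assay the position now has its first readable step: ethyl in place of hydrogen on a saturated chain carbon bound to an oxygen on an unsaturated carbon gives a 1.9-fold lower number from compound 1 to compound 3 (0.27 log units; within the scatter) on the shared core. The methoxy group and the propoxy group therefore cannot be told apart by this measurement, and the position keeps a measurable antiproliferative effect with the propoxy group in place, while compound 2 still has no number and its butyl to propyl step to compound 3 cannot be read. Nothing among the data offered here accounts for how closely the two values lie.

From the compounds shown here alone, what a butoxy group does at this position in this assay remains open, and with two values inside the scatter of each other no trend with chain length can be claimed. Also open, going by these compounds, is how a longer chain such as hexyloxy, or an amine or a carboxylic acid at the end of the alkoxy chain, would read in this assay on the shared core.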